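This account rests on a few compounds, and the source may have more. Where it says the series, first, only, none or still open, it means among the compounds named here.

Measured compounds, with results in a functional assay on HEL cells (Homo sapiens) for inhibition; on this read-out lower numbers stand for stronger inhibition and higher numbers for weaker inhibition:
- compound 1 `CC(C)c1cc(-c2n[nH]c(=O)n2-c2ccc(C(=O)NCCCC(=O)NO)cc2)c(O)cc1O`, compound 1 gives 4600 nM
- compound 2 `CC(C)c1cc(-c2n[nH]c(=O)n2-c2cccc(C(=O)NCCCC(=O)NO)c2)c(O)cc1O`, compound 2 gives 4600 nM

Compound 1 stands level with compound 2 at the digits given; the two values show no difference beyond the usual scatter, so no order between them can be claimed. For the measured compounds named here, no step between measured compounds is available, and nothing in these two numbers speaks to the effect of lengthening the chain that carries the hydroxycarbamoyl group.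

Compound 3 `CC(C)c1cc(-c2n[nH]c(=O)n2-c2ccc(C(=O)NCCCCCC(=O)NO)cc2)c(O)cc1O` is the next compound for this assay. It differs from compound 1 in one place: 2-(hydroxycarbamoyl)ethyl in place of hydroxycarbamoyl on a saturated chain carbon, three bonds along the chain from an amide-type nitrogen. Going by the values given here, with no measured step to draw on, the expectation rests on the structural change alone. A step toward stronger inhibition is expected, of moderate size, though a result within the scatter of compound 1 cannot be excluded. The step expected from this change is a 3.1-fold lower number from compound 1 to compound 3 (0.49 log units; beyond the scatter) in this assay. For compound 3 the estimated value in this assay is 1500 nM, with a range from 400 nM to 6000 nM.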

Compound 3, half-maximal inhibitory concentration: 4600 nM
The estimate for compound 3 lay 3.1-fold (0.49 log units) below the measured number; low and high end bracket the measured number.
By their numbers in this assay, from the lowest: compounds 1, 2 and 3 (each within the scatter of the next).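

In this assay, for the compounds shown here, the change from hydroxycarbamoyl to 2-(hydroxycarbamoyl)ethyl, on a saturated chain carbon three bonds along the chain from an amide-type nitrogen, reads no change at the digits printed from compound 1 to compound 3 (within the scatter) and gives the first direct look at the length of the chain that carries the hydroxycarbamoyl group. On the core of compound 1, this one extension leaves the read-out within the scatter, so this position shows no measurable response to the added chain length in this comparison. No supporting data bear on the result, and its basis remains unassigned.

Going by these compounds, whether the read-out stays the same across other lengths remains open, including a shorter chain or a longer chain ending in hydroxycarbamoyl, as does the outcome of the same extension on compound 2. Also open, on these data alone, is how this position responds when a carboxylic acid or an amine stands at the end of the chain in place of hydroxycarbamoyl.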